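From methoxy to trifluoromethyl at the top of the range

The source may hold more compounds than are shown below. What is called first, only, known or untested is meant among the compounds shown, and "the series" means these compounds.

In an ADME assay on HepG2 2.2.15 cells (Homo sapiens) for cytotoxicity (a higher number here means that more compound is tolerated, a lower number that less compound is tolerated), compound 1 `O=C(OCCc1c(-c2ccccc2Cl)c2cc(Cl)ccc2[nH]c1=O)c1ccccc1` gives 43000 nM. Compound 2 `COc1cccc(/C=C/C(=O)OCCc2c(-c3ccccc3Cl)c3cc(Cl)ccc3[nH]c2=O)c1` is known only as a limit, > 1300000 nM, so it has no exact value and stands at the tolerated end of the two results. Among the compounds with values here, the only measured step is an at least 30-fold higher number from compound 1 to compound 2 (1.48 log units; beyond the scatter). As far as these compounds go, that step is large, and its full size remains open given (the limit of > 1300000 nM in this assay, at which 1 of the 2 values shown sits).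

Compound 3 `O=C(/C=C/c1cccc(C(F)(F)F)c1)OCCc1c(-c2ccccc2Cl)c2cc(Cl)ccc2[nH]c1=O` differs from compound 2 in one place: trifluoromethyl in place of methoxy on an aromatic carbon. Trifluoromethyl stands in place of methoxy on an aromatic carbon, meta to a large group. Within the data shown here, no measured step makes this exchange, so the evidence is indirect. Compound 3 keeps the ethenyl link that came with an at least 30-fold higher number from compound 1 to compound 2 (1.48 log units; beyond the scatter), and it is therefore expected to remain much nearer compound 2 than compound 1. With so little to go on, only a moderate loss of tolerance or no visible change is expected, and the assay may again return only a limit. The expected change is an at least 2.1-fold lower number from compound 2 to compound 3 (0.33 log units; beyond the scatter). For compound 3 the estimated half-maximal cytotoxic concentration in this assay is 600000 nM, with an expected range of 100000 nM to 1500000 nM.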

Compound 3, half-maximal cytotoxic concentration: > 1400000 nM
Compound 3 ended at the assay's limit; the forecaster's own chance of this, stated with the estimate: 40%; middle value at least 2.3-fold (0.36 log units) from the limit.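

In this assay, 2-(3-(trifluoromethyl)phenyl)ethenyl in place of phenyl on a carbonyl carbon gives an at least 32-fold higher number from compound 1 to compound 3 (1.51 log units; beyond the scatter), so the large step is not confined to the compound that carries methoxy. Compound 3 is known only as a limit, > 1400000 nM, and the full size of this step therefore stays open: the limit of > 1400000 nM in this assay, at which 1 of the 3 values shown sits. The step from methoxy to trifluoromethyl cannot be read, since compound 2 also stands at a limit and neither compound has an exact value: the limit of > 1300000 nM in this assay, at which 1 of the 3 values shown sits.

As far as these compounds go, it remains open whether methoxy and trifluoromethyl differ at all in this assay, and whether the gain over compound 1 needs any group on the aromatic carbon, as a plain 2-phenylethenyl group would show. From the compounds shown here alone, it is also open whether an amine or a carboxylic acid on that same aromatic carbon would stay at the limit or bring the number back into a range where it can be read exactly.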